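Working notes on a four-compound carboxamide series

A few compounds are considered here, and "the series" means these few. Any claim that something is new, unique, unknown or untested is made for them only; others in the source may bear on it.

Measured so far:
compound 1 `COc1cc2c(cc1OC)CN(CCCCNC(=O)c1cn(-c3ccccc3OCCF)nn1)CC2`: 17100 nM
compound 2 `COc1ccc(Cn2cc(C(=O)NCCCCN3CCc4cc(OC)c(OC)cc4C3)nn2)cc1`: 3350 nM
compound 3 `COc1cc2c(cc1OC)CN(CCNC(=O)c1cn(-c3ccccc3OC)nn1)CC2`: 15500 nM

In an assay on membranes from brain for displacement of a labelled ligand from Sigma non-opioid intracellular receptor 1 (Cavia porcellus), read by scintillation counting, with a stated time of 90 min (on this read-out lower numbers stand for stronger inhibition and higher numbers for weaker inhibition), compound 3 stands second highest of the three numbers. Compound 1 gives 17100 nM, which sits within the scatter of compound 3, so the two cannot be told apart. Compound 2 gives 3350 nM, a number clearly lower than that of compound 3, beyond the scatter.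

Compound 4 `COc1cccc(-n2cc(C(=O)NCCN3CCc4cc(OC)c(OC)cc4C3)nn2)c1` is not yet measured. It differs from compound 3 by 3-methoxyphenyl in place of 2-methoxyphenyl on an aromatic nitrogen. Going by the values given here, the only measured step that touches the group on that aromatic nitrogen is a 5.1-fold lower number from compound 1 to compound 2 (0.71 log units; beyond the scatter); there 2-(2-fluoroethoxy)phenyl gave way to 4-methoxybenzyl, a change of a different kind from the one into compound 4, so it bears on the question only loosely. Among the compounds with values here, compounds 1 and 3 both carry a phenyl with a group at the 2-position and both give high numbers; the one compound that does not, compound 2, gives the lowest number. On that slim basis a modest lowering is expected for compound 4, a 1.7-fold lower number from compound 3 to compound 4 (0.24 log units; within the scatter), with wide uncertainty. Compound 4 is estimated at 9000 nM, between 3000 nM and 25000 nM.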

Compound 4, inhibition constant: 76700 nM
The estimate for compound 4 lay 8.5-fold (0.93 log units) below the measured number; the whole stated range lies below it.
By their numbers in this assay, from the lowest: compound 2; then compounds 3 and 1 (each within the scatter of the next); then compound 4.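

In this assay, going by these compounds alone, 3-methoxyphenyl in place of 2-methoxyphenyl on the aromatic nitrogen gives a 4.9-fold higher number from compound 3 to compound 4 (0.69 log units; beyond the scatter) and is the first step in which the group keeps the same heavy atoms, aromatic ring and hydrogen-bond acceptor count. The read-out therefore separates these two isomeric groups at this position, whereas the earlier step, a 5.1-fold lower number from compound 1 to compound 2 (0.71 log units; beyond the scatter), replaced one group with another of a different make-up and could not show this. No measurement at hand accounts for the difference between these two groups.

The compounds shown leave open how 4-methoxyphenyl or an unsubstituted phenyl would read on the same core and shorter chain, and so whether the numbers follow any trend across the phenyl ring. They also leave open whether the step from 2-methoxyphenyl to 3-methoxyphenyl would have the same size on the longer chain of compounds 1 and 2, where neither group is paired with its isomer.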